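A few compounds are considered here, and "the series" means these few. Any claim that something is new, unique, unknown or untested is made for them only; others in the source may bear on it.

Working notes on the series.

Compound 3 `CC1=CCCC(C)(C)C1/C=C/C(=O)/C=C/c1ccccc1F` gives 1600 nM in a functional assay on LNCaP cells (Homo sapiens) for cytotoxicity, read by MTT assay, with a stated time of 72 h; a higher number here means a weaker inhibitor, a lower number a stronger inhibitor. That places compound 3 second highest of the three numbers measured: its nearest neighbour is compound 2 `CC1=CCCC(C)(C)C1/C=C/C(=O)/C=C/c1cccc(C(F)(F)F)c1` with 1000 nM, a gap that lies within the scatter, and furthest from it stands compound 1 `CC1=CCCC(C)(C)C1/C=C/C(=O)/C=C/c1ccccc1C(F)(F)F` with 22600 nM, a gap well beyond the scatter.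

Going by the values given here, the only step with a single change in this set is a 14-fold lower number from compound 1 to compound 3 (1.15 log units; beyond the scatter), so a trifluoromethyl group sitting where compound 1 carries it is clearly unfavourable next to a fluoro group at that same carbon. Compound 2 shows that a trifluoromethyl group can be carried elsewhere on the aromatic ring with a number close to that of compound 3.

Compound 4 `CC1=CCCC(C)(C)C1/C=C/C(=O)/C=C/c1cc(C(F)(F)F)ccc1F` differs from compound 3 by trifluoromethyl in place of hydrogen on an aromatic carbon. Among the compounds with values here, no measured step isolates exactly this change; the step from compound 1 to compound 3 concerns a different carbon, and compound 2 only shows that a trifluoromethyl group on the ring can be tolerated. For compound 4 a step of about a 1.5-fold lower number from compound 3 to compound 4 (0.16 log units; within the scatter) is therefore expected, that is nothing beyond the scatter, with a slight lean toward compound 2. Compound 4 is expected to give about 1100 nM in this assay, in the range 400 nM to 3000 nM.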

Compound 4, half-maximal inhibitory concentration: 1700 nM
For compound 4 the middle estimate is 1.5-fold (0.19 log units) below the measured one; the measured number falls inside the stated range.
By their numbers in this assay, from the lowest: compounds 2, 3 and 4 (each within the scatter of the next); then compound 1.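

In this assay, a trifluoromethyl group on this aromatic carbon, para to a fluoro group and meta to a large group, is tolerated: the change gives a 1.1-fold higher number from compound 3 to compound 4 (0.03 log units; within the scatter) and so adds four heavy atoms without a shift beyond the scatter. The pair read the other way gives the same picture for the fluoro group, with a 1.7-fold higher number from compound 2 to compound 4 (0.23 log units; within the scatter), so in these two pairs each group can be carried on the ring when the other is already present. Nothing measured here accounts for this tolerance.

Open, as far as these compounds go, is whether an amine, a carboxylic acid or a nitrile on this same carbon would also stay within the scatter of the trifluoromethyl group. Also open, from the compounds shown here alone, is whether a longer chain there would be tolerated in the same way.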